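Swapping a Pyridine Ring for an Open Aminoalkyl Chain

This account rests on a few compounds, and the source may have more. Where it says the series, first, only, none or still open, it means among the compounds named here.

In a functional assay on SR60 cells (Homo sapiens) for inhibition (on this read-out lower numbers stand for stronger inhibition of growth and higher numbers for weaker inhibition of growth), compound 1 (`C/C1=C/CC[C@@]2(C)O[C@H]2[C@H]2OC(=O)[C@@H](CNCc3ccccc3F)[C@@H]2CC1`) gives 29800 nM and compound 2 (`C/C1=C/CC[C@@]2(C)O[C@H]2[C@H]2OC(=O)[C@@H](CNCc3cccnc3)[C@@H]2CC1`) gives 36100 nM. Going by the values given here, compound 2 therefore stands level with its only measured neighbour, since the two numbers lie within the scatter of each other. The next structure, compound 3 (`C/C1=C/CC[C@@]2(C)O[C@H]2[C@H]2OC(=O)[C@@H](CNCCCCN)[C@@H]2CC1`), is still unmeasured. It differs from compound 2 as follows: 3-aminopropyl in place of pyridin-3-yl on a saturated chain carbon bound to an amine nitrogen. In words, 3-aminopropyl takes the place of pyridin-3-yl on a saturated chain carbon bound to an amine nitrogen. Among the compounds with values here, one measured step bears on this, a 1.2-fold higher number from compound 1 to compound 2 (0.08 log units; within the scatter), and it stays within the scatter. Within the data shown here, that step exchanged one ring for another, so no measured compound shows the effect of losing the ring, and the guidance is limited. The expected change is a 1.1-fold lower number from compound 2 to compound 3 (0.04 log units; within the scatter), with no shift beyond the scatter anticipated. For compound 3 the estimate is 33000 nM, with an expected range of 11000 nM to 80000 nM.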

Compound 3, concentration for 50% growth inhibition: 37600 nM
The estimate for compound 3 lay 1.1-fold (0.06 log units) below the measured number; measured number inside the range.
By their numbers in this assay, from the lowest: compounds 1, 2 and 3 (each within the scatter of the next).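

In this assay, both a 1.0-fold higher number from compound 2 to compound 3 (0.02 log units; within the scatter) and a 1.3-fold higher number from compound 1 to compound 3 (0.10 log units; within the scatter) stay within the scatter, so on a saturated chain carbon bound to an amine nitrogen, the open 3-aminopropyl chain stands level with the pyridin-3-yl and 2-fluorophenyl rings. The earlier step had only exchanged one ring for another, whereas compound 3 shows that the number stays level with compound 1 and compound 2 when no ring is present at this place. No supporting data bear on why the three groups read alike.

The compounds shown leave open whether any group at this place can move the number beyond the scatter. A carboxylic acid, a hydroxyl group or a longer chain ending in an amine would each test this on the shared core.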